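The compounds below may be only part of what the source reports. "The series", "measured", "known", "first", "only" and "open" are said of these compounds alone.

In a toxicity assay on MT4 cells (Homo sapiens) for cytotoxicity, read by MTT assay, with a stated time of 5 days (a lower number here means that less compound is tolerated, a higher number that more compound is tolerated), compound 1 `Cc1cnc(Nc2ccc(C#N)cc2)nc1Nc1c(F)cc(-c2ccoc2)cc1F` gives 4200 nM and compound 2 `Cc1cnc(Nc2ccc(C#N)cc2)nc1Nc1c(F)cc(-c2ccsc2)cc1F` gives 261000 nM, the higher of the two numbers. A third compound, compound 3 `Cc1cnc(Nc2ccc(C#N)cc2)nc1Nc1c(F)cc(-c2ccc(C#N)nc2)cc1F`, has not yet been measured. It differs from compound 2 by 6-cyanopyridin-3-yl in place of thiophen-3-yl on an aromatic carbon, with 6-cyanopyridin-3-yl in place of thiophen-3-yl on an aromatic carbon. Among the measured compounds shown here, only one measured step bears on this change, a 62-fold higher number from compound 1 to compound 2 (1.79 log units; beyond the scatter), a large step beyond the scatter, with thiophen-3-yl in place of furan-3-yl on that same carbon. It shows that the number in this assay can move far with the group here, though no six-membered ring has been measured in this place. With compound 2 at the top of the two numbers, a large downward step is expected, somewhat smaller than that one, and the expected step is a 13-fold lower number from compound 2 to compound 3 (1.12 log units; beyond the scatter). The estimated value for compound 3 is 20000 nM, within a range of 3000 nM to 150000 nM.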

Compound 3, half-maximal cytotoxic concentration: 62000 nM
The estimate for compound 3 lay 3.1-fold (0.49 log units) below the measured number, and the stated range covers the measured number.
By their numbers in this assay, from the lowest: compound 1; then compound 3; then compound 2.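

In this assay a six-membered aromatic ring on this carbon, 6-cyanopyridin-3-yl, gives a number inside the span set by the two five-membered aromatic rings, with a 4.2-fold lower number from compound 2 to compound 3 (0.62 log units; beyond the scatter) on one side and a 15-fold higher number from compound 1 to compound 3 (1.17 log units; beyond the scatter) on the other. Ring size alone therefore does not set the number here, since furan-3-yl and thiophen-3-yl, both five-membered aromatic rings with one hetero atom, lie further apart than either lies from the six-membered group. Nothing available explains why the three groups fall in this order.

Going by these compounds, what a plain pyridin-3-yl, a phenyl ring or an aminomethyl group would give on this carbon stays open, so the share of the nitrile cannot be separated from that of the six-membered ring. On these data alone, whether this order would hold without the two fluoro groups also stays open.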